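Working notes: methyl in place of nitro on the series

This account rests on a few compounds, and the source may have more. Where it says the series, first, only, none or still open, it means among the compounds named here.

In a functional assay on HepG2 cells (Homo sapiens) for inhibition, read by MTT assay, with a stated time of 48 h (on this read-out lower numbers stand for stronger inhibition and higher numbers for weaker inhibition), compound 1 (`COc1cc(C(=O)/C=C/c2cccc(O)c2)cc(OC)c1OC`) gives 94000 nM and compound 2 (`COc1cc(C(=O)/C=C/c2ccc(Br)cc2)cc(OC)c1OC`) gives 80000 nM on the same read-out. The step between them reads a 1.2-fold lower number from compound 1 to compound 2 (0.07 log units; within the scatter) and so shows no real change.

Compound 3 (`COc1cc(C(=O)/C=C/c2ccc([N+](=O)[O-])cc2)cc(OC)c1OC`) gives > 100000 nM as a limit of the assay and not a number. Where compound 3 stands is therefore known only as a limit (the limit of > 100000 nM in this assay, at which 1 of the 3 values shown sits). The step leading to it reads an at least 1.2-fold higher number from compound 2 to compound 3 (0.09 log units; that floor lies within the scatter) and shows nothing beyond the scatter.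

Compound 4 (`COc1cc(C(=O)/C=C/c2ccc(C)cc2)cc(OC)c1OC`) carries methyl in place of nitro on an aromatic carbon, para to a large group. Both measured steps bear on this change, and neither goes beyond the scatter. Compound 2 with its bromo group at 80000 nM offers the closest number, so compound 4 is expected in that region, and no step beyond the scatter is expected in this assay for this exchange. The expected step is an at least 1.3-fold lower number from compound 3 to compound 4 (0.12 log units; that floor lies within the scatter) and points, if anywhere, to a lower number. For compound 4 the estimated value is 75000 nM with an expected range from 40000 nM to 100000 nM on this read-out.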

Compound 4, half-maximal inhibitory concentration: 52000 nM
Beside the measured number, compound 4's estimate is 1.4-fold (0.16 log units) above it; the measured number falls inside the stated range.
By their numbers in this assay, from the lowest: compounds 4, 2 and 1 (each within the scatter of the next). At a limit, above all of these: compound 3.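

In this assay, methyl in place of nitro on an aromatic carbon, para to a large group, replaces a limit with a number, but the step reads an at least 1.9-fold lower number from compound 3 to compound 4 (0.28 log units; that floor lies within the scatter), so only a floor is known for this exchange. Compound 3 remains a limit of the assay and not a number: the limit of > 100000 nM in this assay, at which 1 of the 4 values shown sits. The methyl group also does not separate compound 4 from the two other compounds with numbers, as the steps read a 1.5-fold lower number from compound 2 to compound 4 (0.19 log units; within the scatter) and a 1.8-fold lower number from compound 1 to compound 4 (0.26 log units; within the scatter), so methyl, bromo and the 3-hydroxyphenyl variant cannot be told apart in this assay.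

The true size of the step between nitro and methyl stays open, and no step in this set is shown to lie beyond the scatter. As far as these compounds go, it also stays open whether an amine or a carboxylic acid on this aromatic carbon, or a longer chain such as propyl in place of methyl, would move the number beyond the scatter on the shared core.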